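Swapping fluoro for butoxy in a cell tolerance test

This account rests on a few compounds, and the source may have more. Where it says the series, first, only, none or still open, it means among the compounds named here.

Compound 1 `O=C(Nc1ncc([N+](=O)[O-])s1)NC1CCCCC1`: > 1000000 nM, a limit
Compound 2 `O=C(Nc1ccc(F)cc1)Nc1ncc([N+](=O)[O-])s1`: > 1000000 nM, a limit

In an ADME assay on Vero cells (Chlorocebus sabaeus) for cytotoxicity, read by sulforhodamine B assay, with a stated time of 48 h (a higher number here means that more compound is tolerated, a lower number that less compound is tolerated), compound 2 `O=C(Nc1ccc(F)cc1)Nc1ncc([N+](=O)[O-])s1` gives > 1000000 nM, which is a limit and not a number. This is the limit of > 1000000 nM in this assay, at which 2 of the 2 values shown sit.

Compound 3 `CCCCOc1ccc(NC(=O)Nc2ncc([N+](=O)[O-])s2)cc1` carries butoxy in place of fluoro on an aromatic carbon, para to a large group (butoxy in place of fluoro on an aromatic carbon).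

Going by the values given here, no measured step shows what such a swap does in this assay, so little or no change beyond the scatter is expected, and any shift would be toward less compound tolerated. The expected step is an at least 1.6-fold lower number from compound 2 to compound 3 (0.22 log units; that floor lies within the scatter). For compound 3 the estimate is 600000 nM, with an expected range from 150000 nM to 1000000 nM.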

Compound 3, half-maximal cytotoxic concentration: 58000 nM
Beside the measured number, compound 3's estimate is 10-fold (1.01 log units) above it; the measured number lies below the stated range.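

In this assay, going by these compounds alone, the earlier compounds both sat at the limit and gave no sign that the group at this position matters. Replacing fluoro with butoxy gives an at least 17-fold lower number from compound 2 to compound 3 (1.23 log units; beyond the scatter), so the group on this aromatic carbon can change how much compound the cells tolerate. The true size of the step stays unknown because compound 2 gives only a limit: the limit of > 1000000 nM in this assay, at which 2 of the 3 values shown sit.

Going by these compounds, it remains open whether the length of the chain or its oxygen link matters more. A methoxy group or a plain butyl chain at this position would help separate the two.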